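Swapping Fluoro for Nitro on the Shared Core

The source may report more compounds than this note shows. Statements on the series, on what has been measured and on what is new or still open speak of the compounds shown alone.

Compound 1 `O=C(N/N=C/c1ccc(Cl)cc1)c1cccnc1` and compound 2 `O=C(N/N=C/c1ccc(F)cc1)c1cccnc1` share one core and differ only in one group on an aromatic carbon. In an ADME assay on HEL cells (Homo sapiens) for cytotoxicity, read by microscopy (on this read-out lower numbers stand for higher toxicity in this test and higher numbers for lower toxicity in this test), compound 1 gives 29 ug/mL. Compound 2 in this assay reaches only a limit of the test, > 100 ug/mL, so its true number is not known. The step of an at least 3.4-fold higher number from compound 1 to compound 2 (0.53 log units; beyond the scatter) thus points toward lower toxicity, though its full size stays hidden by the limit of > 100 ug/mL in this assay, at which 1 of the 2 values shown sits. Compound 3 `O=C(N/N=C/c1ccc([N+](=O)[O-])cc1)c1cccnc1` has not yet been measured. It differs from compound 2 by nitro in place of fluoro on an aromatic carbon. Going by the values given here, only that one measured step bears on this change, and it swapped one halogen for another rather than for nitro, so it tells little about what a nitro group does here. With compound 2 known only as a limit, the step of an at least 1.6-fold lower number from compound 2 to compound 3 (0.22 log units; that floor lies within the scatter) is expected with wide uncertainty. Compound 3 is therefore estimated at 60 ug/mL in this assay, within a range from 20 ug/mL to 200 ug/mL, and a fresh limit rather than a number is quite possible.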

Compound 3, half-maximal cytotoxic concentration: < 0.16 ug/mL
Compound 3: only a limit was reported (the forecaster's own chance of this, stated with the estimate: 40%); at least 370-fold (2.57 log units) between middle value and limit.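

In this assay the group on this aromatic carbon, para to a large group, can matter far more than the swap of one halogen for another revealed: nitro in place of fluoro brings an at least 620-fold lower number from compound 2 to compound 3 (2.79 log units; beyond the scatter) and so points toward much higher toxicity in this test. Nitro in place of chloro brings an at least 180-fold lower number from compound 1 to compound 3 (2.25 log units; beyond the scatter) as well, so the sharp fall appears against both halogens and does not depend on which one is replaced. Neither step shows its full size, because compound 3 stands at a limit of the test rather than at a number: the limit of < 0.16 ug/mL in this assay, at which 1 of the 3 values shown sits.

What the compounds shown leave open is whether this sharp fall belongs to nitro alone or would also come with another group on the same carbon, such as an amine, a nitrile or a carboxylic acid. They also leave open what about nitro lies behind the fall, whether nitro elsewhere on that ring would give the same result, and how far the true number of compound 3 lies from its limit.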